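A few compounds are considered here, and "the series" means these few. Any claim that something is new, unique, unknown or untested is made for them only; others in the source may bear on it.

Measured in a functional assay on SK-MEL-2 cells (Homo sapiens) for cytotoxicity, read by sulforhodamine B assay; a lower number here means a stronger inhibitor, a higher number a weaker inhibitor:
Compound 1 `COCCNc1nc(-c2ccccc2)nc2ccccc12`: 27.6 ug/mL
Compound 2 `CC(C)Nc1nc(-c2ccccc2)nc2ccccc12`: 16.5 ug/mL

Compound 2, at 16.5 ug/mL, stands within the scatter of compound 1, so neither compound stands apart from the other on these two numbers. The next compound to be measured is compound 3 `CNc1nc(-c2ccccc2)nc2ccccc12`, which has methyl in place of isopropyl on a nitrogen on an aromatic ring. Among the compounds with values here, only one measured step bears on this change, since it also alters the group on that nitrogen: a 1.7-fold lower number from compound 1 to compound 2 (0.22 log units; within the scatter). Within the data shown here, that single step is small, and no measured step yet shows what a methyl group does here. No shift beyond the scatter is therefore expected in this assay. The expected step is a 1.2-fold higher number from compound 2 to compound 3 (0.08 log units; within the scatter). For compound 3 the estimated value is 20 ug/mL, with an expected range from 9 ug/mL to 45 ug/mL.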

Compound 3, half-maximal inhibitory concentration: 24.4 ug/mL
For compound 3 the middle estimate is 1.2-fold (0.09 log units) below the measured one; low and high end bracket the measured number.
By their numbers in this assay, from the lowest: compounds 2, 3 and 1 (each within the scatter of the next).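

In this assay, within the data shown here, the first measured change confined to the alkyl group on this nitrogen, methyl in place of isopropyl, gives a 1.5-fold higher number from compound 2 to compound 3 (0.17 log units; within the scatter). Removing the methoxymethyl from the 2-methoxyethyl group likewise gives a 1.1-fold lower number from compound 1 to compound 3 (0.05 log units; within the scatter), so methyl, isopropyl and 2-methoxyethyl on this nitrogen cannot be told apart on these numbers, and neither change shows a measurable effect at this position. Nothing at hand offers an explanation for these three numbers.

Going by these compounds, whether any group at this position can move the number beyond the scatter remains open, for example a longer chain ending in an amine, or a carboxylic acid. The compounds shown also leave open what a fluorine or methoxy group on the phenyl substituent would do, as all three carry that group unchanged.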